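Two Limits and a Fluoro Swap

The source may hold more compounds than are shown below. What is called first, only, known or untested is meant among the compounds shown, and "the series" means these compounds.

Measured in an ADME assay on J774 cells (Mus musculus) for cytotoxicity, read by fluorescence and resazurin assay, with a stated time of 24 h; on this read-out higher numbers stand for lower toxicity in this test and lower numbers for higher toxicity in this test:
Compound 1 `O=S(=O)(Nc1cccc2cnccc12)c1cccc2ccccc12`: >= 300000 nM, a limit
Compound 2 `O=[N+]([O-])c1ccc(S(=O)(=O)Nc2ccc3nccnc3c2)cc1`: >= 300000 nM, a limit

Compound 2 reaches no exact number and, like compound 1, sits at the limit of >= 300000 nM in this assay, at which 2 of the 2 values shown sit. Compound 3 `O=S(=O)(Nc1ccc2nccnc2c1)c1ccc(F)cc1` differs from compound 2 in one place: fluoro in place of nitro on an aromatic carbon. Within the data shown here, no measured step shows what this change does. Resting on compound 2 at >= 300000 nM, a limit, no shift beyond the scatter is expected in this assay. The expected change is an at least 1.2-fold lower number from compound 2 to compound 3 (0.07 log units; that floor lies within the scatter). Compound 3 is estimated at 250000 nM, with an expected range from 90000 nM to 300000 nM.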

Compound 3, half-maximal cytotoxic concentration: 43900 nM
Compound 3: the middle estimate sits 5.7-fold (0.76 log units) above what was measured, and the stated range ends above it.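

In this assay, compounds 1 and 2 gave only limits, so neither showed whether the group at this position matters. Fluoro in place of nitro on this aromatic carbon gives an at least 6.8-fold lower number from compound 2 to compound 3 (0.83 log units; beyond the scatter), which shows that this position can change the result, with the lower number standing for higher toxicity in this test. That size is only a floor, since compound 2 stands at a limit: the limit of >= 300000 nM in this assay, at which 2 of the 3 values shown sit. As far as these compounds go, how an amine or a carboxylic acid at this position would read stays open. So does whether this swap acts alike on another core.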